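This account rests on a few compounds, and the source may have more. Where it says the series, first, only, none or still open, it means among the compounds named here.

Measured compounds:
compound 1 `O=C1N/C(=C\c2ccc(O)cc2)C(=O)N1c1ccc(I)cc1` — 25500 nM
compound 2 `O=C1N/C(=C\c2ccc(Cl)cc2)C(=O)N1c1ccc(Cl)cc1` — 35600 nM
compound 3 `COc1cccc(N2C(=O)N/C(=C\c3ccc(O)cc3)C2=O)c1` — > 200000 nM

In a functional assay on NCI-H292 cells (Homo sapiens) for antiproliferative activity (on this read-out higher numbers stand for weaker inhibition and lower numbers for stronger inhibition), compound 1 gives 25500 nM and compound 2 gives 35600 nM. For compound 3 this assay reports only a limit, > 200000 nM, not a number; compound 3 thus stands at the weak end of the three values shown (the limit of > 200000 nM in this assay, at which 1 of the 3 values shown sits). The step to compound 4 `Cc1cccc(N2C(=O)N/C(=C\c3ccc(O)cc3)C2=O)c1` is methyl in place of methoxy on an aromatic carbon, meta to a large group. Among the compounds with values here, no measured pair differs in this way, so there is no step to lean on. The change is small in what it removes and adds, and compound 3 gives no number to move from; the expectation is a step within the scatter, with no direction of its own, so the value of compound 4 is estimated as 200000 nM (range 60000 nM to 500000 nM), a step of a number no higher from compound 3 to compound 4 (the limit leaves the size open) from the limit of compound 3. A reported limit rather than a number is considered the more probable outcome for compound 4.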

Compound 4, half-maximal inhibitory concentration: > 200000 nM
Compound 4: no number, only a limit; the forecaster's own chance of this, stated with the estimate: 60%; the middle value lies on the limit itself.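

In this assay compound 4 gives > 200000 nM, a limit of the assay and not a number. The swap of methoxy for methyl, on an aromatic carbon meta to a large group, cannot be read, since both compounds carry only a limit, so neither group can be ranked against the other at this position, and the limit now recurs: the limit of > 200000 nM in this assay, at which 2 of the 4 values shown sit.

The series now has its first readable step at the aryl group on the ring nitrogen: 3-methylphenyl in place of 4-iodophenyl gives an at least 7.8-fold higher number from compound 1 to compound 4 (0.89 log units; beyond the scatter).

That step leaves open whether the iodo group itself or its place on the aromatic ring matters, as the two change together here. From the compounds shown here alone, it is also open whether an amine or a carboxylic acid on that same aromatic carbon would give a measurable number in this assay.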